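Oxime ether to oxadiazole swap on the aminopyridine series

The compounds below may be only part of what the source reports. "The series", "measured", "known", "first", "only" and "open" are said of these compounds alone.

Measured so far:
compound 1 `CCO/N=C/c1cc(C)c(OCCC(C)CCN2CCN(c3ccnc(N)c3)C2=O)c(C)c1` — 12900 nM
compound 2 `CCO/N=C/c1ccc(OCCCCCN2CCN(c3ccnc(N)c3)C2=O)cc1` — 59000 nM

In an ADME assay on RD cells (Homo sapiens) for cytotoxicity, read by MTT assay, with a stated time of 24 h (on this read-out lower numbers stand for higher toxicity in this test and higher numbers for lower toxicity in this test), compound 1 gives 12900 nM, the lower of the two numbers shown; compound 2 gives 59000 nM, a gap beyond the scatter. Compound 3 `CCc1nc(-c2cc(C)c(OCCC(C)CCN3CCN(c4ccnc(N)c4)C3=O)c(C)c2)no1` is not yet measured. It differs from compound 1 by a group of 7 heavy atoms (4 carbon, 2 nitrogen, 1 oxygen; one five-membered aromatic ring with 3 hetero atoms) in place of a group of 5 heavy atoms (3 carbon, 1 nitrogen, 1 oxygen; no ring), on an aromatic carbon. Within the data shown here, no measured pair tracks this change, so no direction can be drawn from the data. The step from compound 1 to compound 3 in this assay is expected to be a 1.1-fold lower number from compound 1 to compound 3 (0.03 log units; within the scatter), within the scatter. Compound 3 is estimated at 12000 nM, range 4000 nM to 40000 nM.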

Compound 3, half-maximal cytotoxic concentration: 15700 nM
Beside the measured number, compound 3's estimate is 1.3-fold (0.12 log units) below it; the range from low to high includes it.
By their numbers in this assay, from the lowest: compounds 1 and 3 (each within the scatter of the next); then compound 2.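

In this assay, among these compounds, the step of a 1.2-fold higher number from compound 1 to compound 3 (0.09 log units; within the scatter) lies within the scatter, the first reading on this aromatic carbon, para to a large group. The 5-ethyl-1,2,4-oxadiazol-3-yl group and the oxime ether therefore read alike in this test, on this single pair. Nothing available accounts for this.

Going by these compounds, whether the same swap reads alike on compound 2, without the two methyl groups, stays open. So does the reading of a carboxylic acid or an amine on this aromatic carbon.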